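The compounds below may be only part of what the source reports. "The series", "measured", "known", "first", "only" and "open" are said of these compounds alone.

In an assay for inhibition of serine/threonine-protein kinase PAK 4 (Homo sapiens), read by FRET and Z'-LYTE, with a stated time of 60 min, tested at 0.5 uM, in the presence of a further agent that is not named here (on this read-out lower numbers stand for a weaker effect and higher numbers for a stronger effect at the one concentration tested), compound 1 `CC(C)OC(=O)N1CCN(C(=O)c2nc(Nc3cc(C4CC4)[nH]n3)c3cc(Cl)ccc3n2)C[C@H]1C` gives 26.9% and compound 2 `COC(=O)N1CCN(C(=O)c2nc(Nc3cc(C4CC4)[nH]n3)c3cc(Cl)ccc3n2)C[C@H]1C` gives 73.9%, the higher of the two numbers shown. The step of a number 47 percentage points higher from compound 1 to compound 2 (beyond the scatter) is the only measured one, and it changed the group on the oxygen next to a carbonyl group. Compound 3 `CC(C)C(=O)OCOC(=O)N1CCN(C(=O)c2nc(Nc3cc(C4CC4)[nH]n3)c3cc(Cl)ccc3n2)C[C@H]1C` differs from compound 2 by (isopropylcarbonyl)oxy in place of hydrogen on a saturated chain carbon bound to an oxygen next to a carbonyl group. Since enlarging that same position from methyl to isopropyl lowered the read-out, a further, larger group there is expected to lower it again, so a step of a number 28.9 percentage points lower from compound 2 to compound 3 (beyond the scatter) is estimated. Compound 3 is therefore expected to give about 45%, between 20% and 70%.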

Compound 3, a percentage reported as inhibition, at one concentration (the size of the read-out at that concentration, not a potency): 16.4%
Estimate against measurement, compound 3: 28.6 percentage points above; the whole stated range lies above it.
By their numbers in this assay, from the lowest: compound 3; then compound 1; then compound 2.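

In this assay the (isopropylcarbonyl)oxy group on this saturated chain carbon gives a number 57.5 percentage points lower from compound 2 to compound 3 (beyond the scatter) and so takes the read-out past the loss seen with isopropyl. Set against isopropyl, the ((isopropylcarbonyl)oxy)methyl group still gives a number 10.5 percentage points lower from compound 1 to compound 3 (beyond the scatter) and so sits under both smaller groups on the oxygen next to a carbonyl group. Nothing shown explains this drop. Left open is whether ethyl on that oxygen would keep the read-out of compound 2. Also open, going by these compounds, is whether a plain butyl chain or methoxymethyl would lower it as far as compound 3 does.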